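Swapping the aryl group on a shared core

A few compounds are considered here, and "the series" means these few. Any claim that something is new, unique, unknown or untested is made for them only; others in the source may bear on it.

Compound 1 `CCS(=O)(=O)Nc1cc(-c2ccc3ncnc(Nc4ccc(OC(F)(F)F)cc4)c3c2)cnc1OC`: 6140 nM
Compound 2 `CCS(=O)(=O)Nc1cc(-c2ccc3ncnc(Nc4ccc(OC)c(Cl)c4)c3c2)cnc1OC`: 2810 nM
Compound 3 `CCS(=O)(=O)Nc1cc(-c2ccc3ncnc(Nc4cccc(C(=O)OC)c4)c3c2)cnc1OC`: 2400 nM

These three compounds share one core and differ only in the aryl group attached to the nitrogen. In a functional assay on SK-HEP1 cells (Homo sapiens) for cytotoxicity, read by sulforhodamine B assay, with a stated time of 72 h (on this read-out higher numbers stand for weaker inhibition and lower numbers for stronger inhibition), compound 3 stands at the lower end of the three numbers; its gap to compound 2 lies within the scatter, and only its gap to compound 1 lies beyond it. Compound 4 `CCS(=O)(=O)Nc1cc(-c2ccc3ncnc(Nc4ccc(OC)nc4)c3c2)cnc1OC` carries 6-methoxypyridin-3-yl in place of 3-(methoxycarbonyl)phenyl on a nitrogen on an aromatic ring. Going by the values given here, no measured step brings in a methoxypyridine, so the guidance is indirect: a 2.6-fold lower number from compound 1 to compound 3 (0.41 log units; beyond the scatter) and a 2.2-fold lower number from compound 1 to compound 2 (0.34 log units; beyond the scatter) show that exchanging this aryl group shifted the number modestly, while a 1.2-fold lower number from compound 2 to compound 3 (0.07 log units; within the scatter) shows two different groups landing together. The step from compound 3 is therefore expected to be small, a 1.3-fold higher number from compound 3 to compound 4 (0.10 log units; within the scatter). Compound 4 is expected to give 3000 nM, within a range of 1200 nM to 8000 nM.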

Compound 4, half-maximal inhibitory concentration: 3440 nM
Compound 4: middle estimate off by 1.1-fold (0.06 log units), on the low side, within the range that was stated.
By their numbers in this assay, from the lowest: compounds 3, 2, 4 and 1 (each within the scatter of the next, the first and the last beyond it).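

In this assay, going by these compounds alone, 6-methoxypyridin-3-yl, the only group here with a hetero atom in its aromatic ring, stays within the scatter of all three carbon-only aryl groups (a 1.4-fold higher number from compound 3 to compound 4 (0.16 log units; within the scatter); a 1.2-fold higher number from compound 2 to compound 4 (0.09 log units; within the scatter); a 1.8-fold lower number from compound 1 to compound 4 (0.25 log units; within the scatter)). At this place on the nitrogen, then, a ring nitrogen and a group with fewer heavy atoms than 3-(methoxycarbonyl)phenyl bring no step beyond the scatter. No measurement shown here explains this result.

Still open, going by these compounds, is what an aryl group carrying an amine or a carboxylic acid would give at this place.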